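Swapping a benzyloxy for phenylsulfanyl on a nucleoside core

The source may report more compounds than this note shows. Statements on the series, on what has been measured and on what is new or still open speak of the compounds shown alone.

Measured so far:
- compound 1 `O=[N+]([O-])c1cccc2c1CN(c1ncnc3c1nc1n3[C@@H]3O[C@H](CO1)[C@@H](O)[C@H]3O)CC2` gives 1740000 nM
- compound 2 `Nc1ncnc2c1ncn2[C@@H]1O[C@H](COCCOCCNc2ncnc3c2ncn3[C@@H]2O[C@H](CO)[C@@H](O)[C@H]2O)[C@@H](O)[C@H]1O` gives 912000 nM
- compound 3 `OC[C@H]1O[C@@H](n2cnc3c(OCc4ccccc4)ncnc32)[C@H](O)[C@@H]1O` gives 2090 nM

All three numbers come from an assay on isolated protein for binding affinity to Equilibrative nucleoside transporter 1 (Homo sapiens); on this read-out higher numbers stand for weaker inhibition and lower numbers for stronger inhibition. Of the three, compound 3 has the lowest number, and its gaps to compound 2 and to compound 1 both lie well beyond the scatter of repeated measurements, so compound 3 is the strongest inhibitor among them. Within the data shown here, compound 1 and compound 2 share little structure with compound 3 beyond the sugar, and no single-change step between any two measured compounds exists, so there is no measured step to lean on.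

Compound 4 `OC[C@H]1O[C@@H](n2cnc3c(Sc4ccccc4)ncnc32)[C@H](O)[C@@H]1O` differs from compound 3 in exactly one place: phenylsulfanyl in place of benzyloxy on an aromatic carbon. The group on that aromatic carbon keeps one ring and one hydrogen-bond acceptor, but loses the one-carbon link between the core and the ring. Among the measured compounds shown here, nothing among the measured compounds shows how this assay responds to such a change, so the expected step is small: from compound 3 to compound 4 a step within the scatter, or slightly toward weaker inhibition, is expected, a 1.4-fold higher number from compound 3 to compound 4 (0.16 log units; within the scatter). Compound 4 is therefore estimated at 3000 nM, with a range from 500 nM to 20000 nM.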

Compound 4, half-maximal inhibitory concentration: 91200 nM
Compound 4: middle estimate off by 30-fold (1.48 log units), on the low side; measured number outside the range, above it.
By their numbers in this assay, from the lowest: compound 3; then compound 4; then compounds 2 and 1 (each within the scatter of the next).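

In this assay, among these compounds, phenylsulfanyl in place of benzyloxy on an aromatic carbon of the shared core gives a 44-fold higher number from compound 3 to compound 4 (1.64 log units; beyond the scatter), a large step toward weaker inhibition and the first measured single-change step in this set. Among the compounds shown here, both groups carry one six-membered aromatic ring of carbon only, 0 hydrogen-bond donors and 1 hydrogen-bond acceptor, so this position responds strongly to a change that leaves those counts the same, a sensitivity the earlier compounds, with no single-change step among them, could not reveal. No measurement shown here accounts for the size of the step.

The swap alters two things at once, sulfur for oxygen and the loss of the carbon link between the core and the ring, and this single step cannot separate them. Benzylsulfanyl, which keeps the link but carries sulfur, and phenoxy, which keeps oxygen but lacks the link, would each alter just one of the two, and what either would do in this assay remains open.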